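From Ethyl to tert-Butyl on the Shared Core

The compounds below may be only part of what the source reports. "The series", "measured", "known", "first", "only" and "open" are said of these compounds alone.

In a functional assay for inhibition, with Cavia porcellus as the target (a lower number here means a stronger inhibitor, a higher number a weaker inhibitor), compound 2 `CCO/C(O)=C1\C(C)=NC(C)=C([N+](=O)[O-])C1c1ccccn1` gives 5000 nM and compound 1 `CC1=NC(C)=C([N+](=O)[O-])C(c2ccccn2)/C1=C(\O)OCC(C)C` gives 2610 nM, two values within the scatter of each other. Compound 3 `CC1=NC(C)=C([N+](=O)[O-])C(c2ccccn2)/C1=C(\O)OC(C)(C)C` has not yet been measured. It differs from compound 2 as follows: tert-butyl in place of ethyl on an oxygen on an unsaturated carbon. Among the measured compounds shown here, one measured step bears on this change, a 1.9-fold higher number from compound 1 to compound 2 (0.28 log units; within the scatter), and it stays within the scatter. No step beyond the scatter is therefore expected in this assay, in either direction. For compound 3 the expected value is 3500 nM, with an estimated range of 1200 nM to 10000 nM.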

Compound 3, half-maximal inhibitory concentration: 1930 nM
The estimate for compound 3 lay 1.8-fold (0.26 log units) above the measured number; the measured number falls inside the stated range.
By their numbers in this assay, from the lowest: compounds 3, 1 and 2 (each within the scatter of the next, the first and the last beyond it).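

In this assay, among the compounds shown here, tert-butyl in place of ethyl on this oxygen gives a 2.6-fold lower number from compound 2 to compound 3 (0.41 log units; beyond the scatter) and is the first change here to pass beyond the scatter, though only modestly. Tert-butyl in place of isobutyl gives a 1.4-fold lower number from compound 1 to compound 3 (0.13 log units; within the scatter) and so does not separate those two groups. Nothing measured here offers an explanation for these steps.

Going by these compounds, whether a longer chain, or a chain ending in an amine or a carboxylic acid, would carry the trend further on this oxygen remains open.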